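Hydroxy in place of nitro on the second ring

This account rests on a few compounds, and the source may have more. Where it says the series, first, only, none or still open, it means among the compounds named here.

Two compounds of the series carry numbers in an assay on CHO cells for displacement of a labelled ligand from Alpha-2B adrenergic receptor (Homo sapiens); on this read-out higher numbers stand for weaker inhibition and lower numbers for stronger inhibition. Compound 1 `Cc1ccc(-c2ccccc2OC(C)C2=NCCN2)cc1` gives 398 nM. Compound 2 `CC(Oc1ccccc1-c1ccccc1[N+](=O)[O-])C1=NCCN1` gives 1550 nM, the higher of the two numbers; its gap to compound 1 lies beyond the usual scatter, so compound 2 is the weaker binder of the pair. Compound 3 `CC(Oc1ccccc1-c1ccccc1O)C1=NCCN1` is the next member to be measured in this assay. It differs from compound 2 in a single place: hydroxy in place of nitro on an aromatic carbon, ortho to a large group. Going by the values given here, no measured pair shows this exchange, so its size cannot be read from the data at hand. The expectation is a modest move toward a lower number, a step of a 2.1-fold lower number from compound 2 to compound 3 (0.32 log units; beyond the scatter), near the edge of the scatter rather than clearly beyond it. Compound 3 is accordingly estimated at 750 nM, within a range from 220 nM to 2500 nM.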

Compound 3, inhibition constant: 1000 nM
For compound 3 the middle estimate is 1.3-fold (0.12 log units) below the measured one; measured number inside the range.
By their numbers in this assay, from the lowest: compound 1; then compounds 3 and 2 (each within the scatter of the next).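

In this assay, the exchange on this aromatic carbon, ortho to a large group, gives a 1.6-fold lower number from compound 2 to compound 3 (0.19 log units; within the scatter): nitro and hydroxy cannot be told apart here, although the exchange replaces 3 heavy atoms with 1 and brings in a hydrogen-bond donor. The other comparison gives a 2.5-fold higher number from compound 1 to compound 3 (0.40 log units; beyond the scatter), so 4-methylphenyl keeps an edge over 2-hydroxyphenyl, and compound 1 holds the lowest number of the three. Nothing at hand accounts for these numbers.

The step from compound 1 to compound 3 changes both the group and its place on the ring, so the contribution of each remains unresolved. A 2-methylphenyl or 4-hydroxyphenyl group would separate the two, while an unsubstituted phenyl ring would show what any group at these places adds.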